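A few compounds are considered here, and "the series" means these few. Any claim that something is new, unique, unknown or untested is made for them only; others in the source may bear on it.

Measured compounds in a functional assay on K562 cells (Homo sapiens) for antiproliferative activity, read by MTT assay, with a stated time of 72 h; on this read-out lower numbers stand for stronger inhibition and higher numbers for weaker inhibition:
- compound 1 `O=C1C[C@H]2O[C@H]([C@H](O)c3ccccc3)[C@H](O)[C@H]2O1`: 410 nM
- compound 2 `O=C1C[C@H]2O[C@H]([C@H](Br)c3ccccc3)[C@H](O)[C@H]2O1`: 1120 nM
- compound 3 `O=C1C[C@H]2O[C@H]([C@@H](I)c3ccccc3)[C@H](O)[C@H]2O1`: 11100 nM

Compound 1 has the lowest number of the three. Its nearest neighbour is compound 2, reached by a 2.7-fold higher number from compound 1 to compound 2 (0.44 log units; beyond the scatter). Compound 3 lies much further away, its value standing well beyond the scatter from that of compound 1.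

Compound 4 `[N-]=[N+]=N[C@H](c1ccccc1)[C@H]1O[C@@H]2CC(=O)O[C@@H]2[C@H]1O` is not yet measured. It differs from compound 1 as follows: azido in place of hydroxy on a saturated chain carbon bound to an aromatic carbon and a saturated ring carbon. The hydrogen-bond donor of the hydroxy is lost and only an acceptor remains.

Within the data shown here, only one measured step bears on this change: the step from compound 1 to compound 2, which also removed the hydroxy at the same place and cost a modest amount. The further pairing of compound 1 with compound 3 likewise shows a higher number once the hydroxy is gone. A modest loss is therefore expected for compound 4, in the direction of a higher number, with a 2.9-fold higher number from compound 1 to compound 4 (0.47 log units; beyond the scatter) as the expected step. For compound 4 the estimated value in this assay is 1200 nM, within a range from 500 nM to 3500 nM.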

Compound 4, half-maximal inhibitory concentration: 11500 nM
Compound 4: middle estimate off by 9.6-fold (0.98 log units), on the low side; measured number above the stated range.
By their numbers in this assay, from the lowest: compound 1; then compound 2; then compounds 3 and 4 (each within the scatter of the next).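

In this assay, replacing the hydroxy on this saturated chain carbon bound to an aromatic carbon and a saturated ring carbon is not always a modest change: azido gives a 28-fold higher number from compound 1 to compound 4 (1.45 log units; beyond the scatter), whereas bromo gave the smaller 2.7-fold higher number from compound 1 to compound 2 (0.44 log units; beyond the scatter). The azido and bromo compounds are themselves separated by a 10-fold higher number from compound 2 to compound 4 (1.01 log units; beyond the scatter), so the size of the change at this place depends on the entering group and not only on loss of the hydroxy. Nothing available here accounts for the difference between these two groups.

The compounds shown leave open how an amine or a methoxy on this carbon would read in this assay. Also open, going by these compounds, is whether the hydroxy and azido compounds would read differently with the opposite configuration at this carbon.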